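Compound 2 to compound 3, measured against a limit

The source may report more compounds than this note shows. Statements on the series, on what has been measured and on what is new or still open speak of the compounds shown alone.

Compound 1 `O=C(O)c1cccc(S(=O)(=O)N2CCC(NS(=O)(=O)c3cc(S(=O)(=O)c4ccccc4)ccc3C(F)(F)F)CC2)c1`: > 100000 nM (a limit)
Compound 2 `O=C(C1CCNCC1)N1CCC(NS(=O)(=O)c2cc(S(=O)(=O)c3ccccc3)ccc2C(F)(F)F)CC1`: > 100000 nM (a limit)

In a physicochemical assay for solubility, at pH 7.4 (on this read-out higher numbers stand for higher solubility and lower numbers for lower solubility), compound 2 reads > 100000 nM, which is a limit and not a number. Compound 1 reads > 100000 nM, which is also a limit. Together they amount to the limit of > 100000 nM in this assay, at which 2 of the 2 values shown sit.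

Compound 3 `O=C(CC1CCNCC1)N1CCC(NS(=O)(=O)c2cc(S(=O)(=O)c3ccccc3)ccc2C(F)(F)F)CC1` differs from compound 2 in one place: (piperidin-4-yl)methyl in place of piperidin-4-yl on a carbonyl carbon. In words, (piperidin-4-yl)methyl stands in place of piperidin-4-yl on a carbonyl carbon.

Within the data shown here, only one measured step is available, and it is a step that the two limits leave unreadable from compound 1 to compound 2. It replaced a different group, on an amine nitrogen in a ring rather than on a carbonyl carbon, and it offers no size to carry over. The expectation therefore rests on compound 2 at > 100000 nM, a limit that gives only a loose anchor.

No step beyond the usual scatter is expected in this assay, in either direction, and the estimated step is a number no higher from compound 2 to compound 3 (the limit leaves the size open). A report as a limit is the likeliest outcome. For compound 3 the estimated value is 100000 nM, with an expected range from 50000 nM to 200000 nM.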

Compound 3, solubility: > 100000 nM
Compound 3 was reported as a limit; the forecaster's own chance of this, stated with the estimate: 85%; the middle value lies on the limit itself.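

In this assay compound 3 gives > 100000 nM, which is a limit and not a number. The steps linking compound 1, compound 2 and compound 3 therefore cannot be read. Still open is whether (piperidin-4-yl)methyl in place of piperidin-4-yl makes any difference at all, because all three compounds share one reading: the limit of > 100000 nM in this assay, at which 3 of the 3 values shown sit.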